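The source may hold more compounds than are shown below. What is called first, only, known or untested is meant among the compounds shown, and "the series" means these compounds.

Compound 1 `COC(=O)c1sc2cc(C)ccc2c1Nc1cc(OC)c(OC)c(OC)c1` gives 0.6 nM in a functional assay on Jurkat cells (Homo sapiens) for cytotoxicity, read by MTT assay, with a stated time of 72 h; a lower number here means a stronger inhibitor, a higher number a weaker inhibitor.
Compound 2 `COC(=O)c1sc2ncccc2c1Nc1cc(OC)c(OC)c(OC)c1` gives 1110 nM in this assay.
Compound 3 `CCOC(=O)c1sc2cc(C)ccc2c1Nc1cc(OC)c(OC)c(OC)c1` gives 0.4 nM in this assay.

Compound 1 and compound 3 share a core and differ by one change, (methyl in place of hydrogen on a saturated chain carbon bound to an oxygen next to a carbonyl group). That change made a 1.5-fold lower number from compound 1 to compound 3 (0.18 log units; within the scatter). Compound 2 carries a different core; the difference between the two cores is not broken down here. Its number is the highest of the three, so compound 2 is the weakest inhibitor of those measured. Compound 4 `CCOC(=O)c1sc2ncccc2c1Nc1cc(OC)c(OC)c(OC)c1` has not yet been measured. It differs from compound 2 by methyl in place of hydrogen on a saturated chain carbon bound to an oxygen next to a carbonyl group, the same change seen between compound 1 and compound 3, at the same place. Going by the values given here, the only guide is a 1.5-fold lower number from compound 1 to compound 3 (0.18 log units; within the scatter), a small step. On that basis the expected step in this assay is a 1.4-fold lower number from compound 2 to compound 4 (0.14 log units; within the scatter). Compound 4 is therefore estimated at 800 nM, with a range from 250 nM to 2500 nM.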

Compound 4, half-maximal inhibitory concentration: 8450 nM
Compound 4: the middle estimate sits 11-fold (1.02 log units) below what was measured, outside the stated range (above it).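

Going from methoxycarbonyl to ethoxycarbonyl gave a 7.6-fold higher number from compound 2 to compound 4 (0.88 log units; beyond the scatter) in this assay, so the change did not carry over from one core to the other, and its effect differs clearly between them: the same change on two cores in this assay, a 1.5-fold lower number (0.18 log units; within the scatter) from compound 1 to compound 3 and a 7.6-fold higher number (0.88 log units; beyond the scatter) from compound 2 to compound 4, 11-fold (1.06 log units) apart, beyond the scatter of two such steps. A small step on one core therefore did not predict the step on the other. Going by these compounds alone, with only one pair on each core, this does not show why the two cores differ, or how the change would behave on any other core.

Still open, on these data alone, is whether a longer chain in place of the ethyl of ethoxycarbonyl would follow either step. As far as these compounds go, a carboxylic acid in place of the ester is equally open on both cores.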